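The compounds below may be only part of what the source reports. "The series", "measured", "known", "first", "only" and "open" are said of these compounds alone.

Series notes. Compound 1 `CC1=C(C(=O)NCCCN2CCC(c3ccc(F)cc3)CC2)[C@@H](c2ccc(F)c(F)c2)NC(=O)N1`, compound 2 `COCC1=C(C(=O)NCCCN2CCC(c3ccc(F)cc3)CC2)[C@@H](c2ccc(F)c(F)c2)NC(=O)N1`, compound 3 `CC1=C(C(=O)NCCCN2CCC(c3ccc(F)cc3C#N)CC2)[C@@H](c2ccc(F)c(F)c2)NC(=O)N1` and compound 4 `COCC1=C(C(=O)NCCCN2CCC(c3ccc(F)cc3C#N)CC2)[C@@H](c2ccc(F)c(F)c2)NC(=O)N1` share one core and vary at two positions. In an in vivo ADME assay on the whole organism (Rattus norvegicus) for pharmacokinetics (on this read-out higher numbers stand for higher oral bioavailability and lower numbers for lower oral bioavailability), compound 1 gives < 6%, which is a limit of the assay and not a number. In this assay compound 2 gives 26% and compound 3 gives 0%. Compound 2 comes from compound 1 by methoxy in place of hydrogen on a saturated chain carbon bound to a double-bonded ring carbon, and this change made a number at least 20 percentage points higher from compound 1 to compound 2 (beyond the scatter). Compound 3 comes from compound 1 by cyano in place of hydrogen on an aromatic carbon; the resulting step is a step that the limit leaves unreadable from compound 1 to compound 3 because compound 1 sits at the limit of < 6% in this assay, at which 1 of the 3 values shown sits. Compound 4 is not yet measured and comes from compound 3 by methoxy in place of hydrogen on a saturated chain carbon bound to a double-bonded ring carbon, the same change as that from compound 1 to compound 2, at a place described in the same words. For compound 4 the step in this assay is expected to be a number 15 percentage points higher from compound 3 to compound 4 (beyond the scatter). Going by the values given here, this rests on compound 2 alone, whose step a number at least 20 percentage points higher from compound 1 to compound 2 (beyond the scatter) is the only reading of this change, and on the low starting point of compound 3. Compound 4 is therefore estimated at 15% in this assay, with a likely range from 3% to 30%.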

Compound 4, oral bioavailability: < 6%
Compound 4: a limit, no number; the forecaster's own chance of this, stated with the estimate: 25%; middle value at least 9 percentage points away from the limit.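

In this assay compound 4 gives < 6%, which is a limit of the assay and not a number. With methoxy already present, cyano in place of hydrogen on an aromatic carbon gives a number at least 20 percentage points lower from compound 2 to compound 4 (beyond the scatter), so the rise of a number at least 20 percentage points higher from compound 1 to compound 2 (beyond the scatter) on the core of compound 1 does not reappear at that size on the core of compound 3. The steps that touch a limit cannot be read, including the one for the methoxy change on the core of compound 3, so a smaller gain from that change is neither shown nor excluded, because these values stop at the limit: the limit of < 6% in this assay, at which 2 of the 4 values shown sit.

The methoxy change has one readable reading, on the core of compound 1, so no general rule for carrying it across cores follows from these compounds. Still open, as far as these compounds go, is how it behaves with an amine or a carboxylic acid in place of cyano on the aromatic carbon, and whether a longer chain in place of methoxymethyl follows the same course.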